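Changing the Group on the Ring Nitrogen

The compounds below may be only part of what the source reports. "The series", "measured", "known", "first", "only" and "open" are said of these compounds alone.

The study measured three compounds in a functional assay on cells (T-cell, Homo sapiens) for inhibition; a lower number here means a stronger inhibitor, a higher number a weaker inhibitor. Compound 1 `CCOc1nc(N)nc2ncc(-c3ccc(CC)cc3)nc12` gives 8200 nM. For compound 2 `CC(C)Oc1nc(N)nc2ncc(-c3ccc(C#N)cc3)nc12` the assay reports only a limit, > 10000 nM. Compound 3 `COc1ccc(-c2cnc3nc(N)nc(N4CCN(C(=O)c5ccccc5)CC4)c3n2)cc1OC` gives 400 nM, the lowest of the two numbers, with compound 1 the nearest at a gap beyond the usual scatter. Compound 4 `COc1ccc(-c2cnc3nc(N)nc(N4CCN(Cc5c(Cl)cccc5Cl)CC4)c3n2)cc1OC` is not yet measured; it differs from compound 3 by 2,6-dichlorobenzyl in place of benzoyl on an amine nitrogen in a ring. For the measured compounds named here, no step between measured compounds is known, so the expected size of the step in this assay rests on the change alone; a shift within or just beyond the scatter, in either direction, is expected, written as a 1.1-fold lower number from compound 3 to compound 4 (0.06 log units; within the scatter). Compound 4 is therefore estimated at 350 nM, between 70 nM and 1800 nM.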

Compound 4, half-maximal inhibitory concentration: 7600 nM
For compound 4 the middle estimate is 22-fold (1.34 log units) below the measured one; measured number outside the range, above it.
By their numbers in this assay, from the lowest: compound 3; then compounds 4 and 1 (each within the scatter of the next). At a limit, above all of these: compound 2.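

In this assay, for the compounds shown here, the swap of benzoyl for 2,6-dichlorobenzyl on the amine nitrogen in the ring gives a 19-fold higher number from compound 3 to compound 4 (1.28 log units; beyond the scatter) and is the first step in this set that can be read, so this position is not indifferent to the group it carries. That single swap removes the carbonyl and brings in two chlorine atoms. Nothing in the data shown gives a cause for the step. The compounds shown leave open which part of the swap carries the step: a plain benzyl or a 2,6-dichlorobenzoyl group on the same nitrogen would separate the two.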